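Working notes: changing the bicyclic group on compound 1

This account rests on a few compounds, and the source may have more. Where it says the series, first, only, none or still open, it means among the compounds named here.

Measured so far in a functional assay on MIA PaCa-2 cells (Homo sapiens) for antiproliferative activity, read by MTT assay, with a stated time of 72 h; a lower number here means a stronger inhibitor, a higher number a weaker inhibitor:
- compound 1 `O=C1O/C(=C\Cn2cnc3c(F)nc(F)c(Cl)c32)C(OCc2ccccc2)=C1OCc1ccccc1`: 78000 nM
- compound 2 `COc1nc(OC)c2c(ccn2CCC2(O)NC(=O)C(OCc3ccccc3)=C2OCc2ccccc2)n1`: 36600 nM

Of these two, compound 1 carries the higher number and so is the weaker inhibitor, and compound 2 lies lower by a gap just beyond the usual scatter. Both numbers sit far up in the micromolar range.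

Compound 3 `O=C1O/C(=C\Cn2cnc3ncc(Br)c-3c2)C(OCc2ccccc2)=C1OCc1ccccc1` has not yet been measured in this assay. Its structural change from compound 1 is a group of 10 heavy atoms (6 carbon, 3 nitrogen, 1 bromine; one five-membered aromatic ring with 1 hetero atom, one six-membered aromatic ring with 2 hetero atoms) in place of a group of 12 heavy atoms (6 carbon, 3 nitrogen, 2 fluorine, 1 chlorine; one five-membered aromatic ring with 2 hetero atoms, one six-membered aromatic ring with 1 hetero atom), on a saturated chain carbon bound to a double-bonded chain carbon. Among the measured compounds shown here, no measured step covers this swap, so the expectation is loose: a modest move toward a lower number, with no change beyond the scatter also plausible. The expected size is a 2.2-fold lower number from compound 1 to compound 3 (0.35 log units; beyond the scatter). For compound 3 the estimated value is 35000 nM, with an expected range of 8000 nM to 100000 nM.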

Compound 3, half-maximal inhibitory concentration: > 100000 nM
Compound 3 gave a limit, no number; the forecaster's own chance of this, stated with the estimate: 15%; at least 2.8-fold (0.45 log units) between middle value and limit.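

In this assay compound 3 gives > 100000 nM, which is a limit of the assay and not a number. Going by these compounds, the first step read at this place, on a saturated chain carbon bound to a double-bonded chain carbon, is an at least 1.2-fold higher number from compound 1 to compound 3 (0.10 log units; that floor lies within the scatter), so the swap of bicyclic group brings no gain in inhibition, and the true size of the change remains unknown. With this result the series reaches the end of the assay's readable range: the limit of > 100000 nM in this assay, at which 1 of the 3 values shown sits.

The swap exchanges the two fluorines and the chlorine for a bromine and also alters the hetero atoms of both rings, so the step cannot assign the outcome to any one of these changes. On these data alone, how an amine on the bicyclic group or a longer chain at this place would read in this assay remains open.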